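The source may report more compounds than this note shows. Statements on the series, on what has been measured and on what is new or still open speak of the compounds shown alone.

Compound 1, `CC(=O)N[C@@H]1CCC[C@H](C(=O)Nc2cc(-c3cnc4n3CCCC4)c(Cl)cn2)C1`: 600000 nM
Compound 2, `CC(=O)N[C@@H]1CCC[C@H](C(=O)Nc2cc(-c3nnn4ccccc34)c(Cl)cn2)C1`: 530000 nM
Compound 3, `CC(=O)N[C@@H]1CCC[C@H](C(=O)Nc2cc(-c3cnn4c3CC(C)(C)C4)c(F)cn2)C1`: 550000 nM

Among these three, compound 1 holds the highest number in a physicochemical assay for solubility, in phosphate buffer, at pH 7.4 (a lower number here means a less soluble compound, a higher number a more soluble compound), yet neither of the others stands apart from it: compound 3 sits nearest and compound 2 furthest, and both gaps lie within the scatter. Compound 4, `CC(=O)N[C@@H]1CCC[C@H](C(=O)Nc2cc(-c3cnn4c3CC(C)(C)C4)c(Cl)cn2)C1`, has not yet been measured. It differs from compound 1 in one place: a group of 10 heavy atoms (8 carbon, 2 nitrogen; one five-membered non-aromatic ring with 1 hetero atom, one five-membered aromatic ring with 2 hetero atoms) in place of a group of 9 heavy atoms (7 carbon, 2 nitrogen; one five-membered aromatic ring with 2 hetero atoms, one six-membered non-aromatic ring with 1 hetero atom), on an aromatic carbon. Among the measured compounds shown here, the only measured step that bears directly on this exchange is the one at the same position, a 1.1-fold lower number from compound 1 to compound 2 (0.05 log units; within the scatter), which was within the scatter. For the measured compounds named here, compound 3 differs from compound 1 in two places and so offers no single step, but its value against that of compound 1 also shows no difference beyond the scatter. On this basis no step beyond the scatter is expected for compound 4, the estimated step being a 1.1-fold lower number from compound 1 to compound 4 (0.03 log units; within the scatter). Compound 4 is therefore estimated at 560000 nM in this assay, with a range from 300000 nM to 950000 nM.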

Compound 4, solubility: 150000 nM
Compound 4: middle estimate off by 3.7-fold (0.57 log units), on the high side; measured number outside the range, below it.
By their numbers in this assay, from the lowest: compound 4; then compounds 2, 3 and 1 (each within the scatter of the next).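

In this assay, the group at the aromatic carbon opposite the ring nitrogen turns out not to be interchangeable, as the earlier step there had suggested: the group entering in compound 4 gives a 4.0-fold lower number from compound 1 to compound 4 (0.60 log units; beyond the scatter) and a 3.5-fold lower number from compound 2 to compound 4 (0.55 log units; beyond the scatter). Chloro in place of fluoro, a change with no single step among the earlier compounds, gives a 3.7-fold lower number from compound 3 to compound 4 (0.56 log units; beyond the scatter); among these four compounds the lower number appears only where this group and chloro occur together, while compounds 1 and 2 carry chloro without this group and compound 3 carries this group without chloro. Nothing measured here accounts for this result.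

Whether the fall is specific to chloro remains open, since the compounds shown do not tell how a bromo or a methyl group in its place would read. Nor do they show whether an amine on the entering group would change the number.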